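This account rests on a few compounds, and the source may have more. Where it says the series, first, only, none or still open, it means among the compounds named here.

Compound 1 `COc1cccc(C(=O)Nc2cccc(-c3oc4cc(-c5ccc(F)cc5)ccc4c(=O)c3O)c2)c1` gives 5650 nM in a functional assay on HeLa cells (Homo sapiens) for antiproliferative activity, read by CCK-8 assay, with a stated time of 72 h; on this read-out higher numbers stand for weaker inhibition and lower numbers for stronger inhibition. Among the two numbers available, compound 1 holds the lowest; its nearest neighbour is compound 2 `O=C(Nc1cccc(-c2oc3cc(-c4ccc(F)cc4)ccc3c(=O)c2O)c1)c1ccc([N+](=O)[O-])cc1`, which in this assay gives 12300 nM, so the only measured step is a 2.2-fold higher number from compound 1 to compound 2 (0.34 log units; beyond the scatter) through the change to 4-nitrophenyl in place of 3-methoxyphenyl on a carbonyl carbon.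

The step now followed leads from compound 1 to compound 3 `O=C(Nc1cccc(-c2oc3cc(-c4ccc(F)cc4)ccc3c(=O)c2O)c1)c1ccc(-c2ccccc2)cc1`. The change is 4-phenylphenyl in place of 3-methoxyphenyl on a carbonyl carbon. Like the step from compound 1 to compound 2, it exchanges the 3-methoxyphenyl on the carbonyl carbon for a ring bearing a 4-substituent, though here 4-phenylphenyl rather than 4-nitrophenyl, so that step is the one that bears on it. Among the compounds with values here, that measured step was modest, and there is no second step to show whether a different 4-substituent would move the number the other way.

Compound 3 is therefore expected to sit near compound 1 or somewhat higher in this assay, with an expected step of a 1.4-fold higher number from compound 1 to compound 3 (0.15 log units; within the scatter). The estimate for compound 3 in this assay is 8000 nM, within a range from 3000 nM to 25000 nM.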

Compound 3, half-maximal inhibitory concentration: > 100000 nM
Compound 3: only a limit was reported (the forecaster's own chance of this, stated with the estimate: 10%); at least 12-fold (1.09 log units) between middle value and limit.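

In this assay compound 3 is recorded only at a limit of the assay, not at a number: the limit of > 100000 nM in this assay, at which 1 of the 3 values shown sits.

Even read as a limit, the result shows that this position on the carbonyl carbon tolerates some rings far better than others: 4-phenylphenyl gives an at least 17-fold higher number from compound 1 to compound 3 (1.24 log units; beyond the scatter), whereas the only earlier change here, to 4-nitrophenyl, had a modest effect. The comparison within the 4-substituted pair is sharper still, since phenyl in place of nitro on an aromatic carbon gives an at least 8.1-fold higher number from compound 2 to compound 3 (0.91 log units; beyond the scatter), so among these compounds the identity of the 4-substituent, and not merely its presence, sets the read-out.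

The compounds shown leave open where an amine, a carboxylic acid or a single fluorine at the same 4-position would fall relative to compound 1 and compound 2, and so whether the sharp rise is confined to the added phenyl ring. They also leave open how a 4-methoxyphenyl would compare with the 3-methoxyphenyl of compound 1, and how far past its limit compound 3 truly lies.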